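Adding a Second Chloro to the Purine-Type Core

The source may hold more compounds than are shown below. What is called first, only, known or untested is meant among the compounds shown, and "the series" means these compounds.

Of the compounds shown here, three have been tested in a functional assay on OVCAR-4 cells (Homo sapiens) for cytotoxicity, read by sulforhodamine B assay, with a stated time of 48 h; on this read-out lower numbers stand for higher toxicity in this test and higher numbers for lower toxicity in this test. Compound 1 `ClCc1ccc(Cn2cnc3c(Cl)ncnc32)cc1` carries a single chloro on its fused core. For compound 1 the result in this assay is a limit of the assay, > 100000 nM. Compound 3 `ClCc1ccc(Cn2cnc3c(Cl)nc(Cl)nc32)cc1` carries the same change that is asked about below, (chloro in place of hydrogen on an aromatic carbon), and in this assay compound 3 gives 61700 nM. The step of an at least 1.6-fold lower number from compound 1 to compound 3 (0.20 log units; that floor lies within the scatter) therefore rests on a limit and is small.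

Compound 2 `ClCc1cccc(Cn2cnc3ncnc(Cl)c32)c1` has the same atoms as compound 1 joined differently; how the two cores differ is not broken down here. In this assay compound 2 gives 46800 nM, a value within the scatter of that of compound 3.

Compound 4 `ClCc1cccc(Cn2cnc3nc(Cl)nc(Cl)c32)c1` has not yet been measured. It differs from compound 2 by chloro in place of hydrogen on an aromatic carbon, the same change as from compound 1 to compound 3, at a place described in the same words. Because of an at least 1.6-fold lower number from compound 1 to compound 3 (0.20 log units; that floor lies within the scatter), the step from compound 2 to compound 4 is expected to be of similar modest size, a 1.3-fold lower number from compound 2 to compound 4 (0.13 log units; within the scatter). Compound 4 is thus estimated at 35000 nM, between 15000 nM and 80000 nM.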

Compound 4, concentration lethal to 50% of the cells: 5370 nM
The estimate for compound 4 lay 6.5-fold (0.81 log units) above the measured number; the whole stated range lies above it.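

In this assay, chloro in place of hydrogen on the core of compound 2 gives a clear step, an 8.7-fold lower number from compound 2 to compound 4 (0.94 log units; beyond the scatter). This shows that the change can matter in this series, at least on this core, but it does not show that its size carries over from one core to another, nor that it fails to carry over: the same change on two cores in this assay, an at least 1.6-fold lower number (0.20 log units; that floor lies within the scatter) from compound 1 to compound 3 and an 8.7-fold lower number (0.94 log units; beyond the scatter) from compound 2 to compound 4; the limit leaves it open whether they differ. The reading for compound 1 is a limit and not a number, so the earlier step gives only a floor and cannot serve as a full comparison: the limit of > 100000 nM in this assay, at which 1 of the 4 values shown sits.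

The compounds shown leave open whether the drop in the number for compound 4 is specific to chloro, since no other group, such as a fluoro, a methoxy or an amine, stands on that aromatic carbon between the two ring nitrogen atoms. They also leave open how the same change would behave on a further core whose starting value is a number rather than a limit.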